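This account rests on a few compounds, and the source may have more. Where it says the series, first, only, none or still open, it means among the compounds named here.

Of the compounds shown here, three sharing one core have been tested in a functional assay on BT-474 cells (Homo sapiens) for cytotoxicity, read by MTT assay, with a stated time of 48 h; on this read-out lower numbers stand for stronger inhibition and higher numbers for weaker inhibition. Compound 1 `Cc1cc2cc(N/C=C\C(=O)c3nc(-c4ccc(F)cc4)n4ccccc34)ccc2[nH]1` reaches only the limit of the measurement, giving > 30000 nM. Compound 2 `O=C(/C=C\Nc1ccc2cc[nH]c2c1)c1nc(-c2ccc(C(F)(F)F)cc2)n2ccccc12` likewise stops at that limit, giving > 30000 nM. Among the measured compounds shown here, compound 3 `COc1ccc(-c2nc(C(=O)/C=C\Nc3ccc4[nH]ccc4c3)c3ccccn23)cc1` is the one compound with a number rather than a limit, giving 13000 nM. Compound 2 therefore stands at the edge of what the measurement can report, as does compound 1, a point made by the limit of > 30000 nM in this assay, at which 2 of the 3 values shown sit.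

Compound 4 `O=C(/C=C\Nc1ccc(Cl)cc1)c1nc(-c2ccc(C(F)(F)F)cc2)n2ccccc12` has not yet been tested. Its structure differs from compound 2 in one place: 4-chlorophenyl in place of 1H-indol-6-yl on an amine nitrogen. For the measured compounds named here, no step between two measured compounds is available here, so the size of such a change cannot be read from the data, and the limit for compound 2 means that only a move toward stronger inhibition could become visible at all. Compound 4 is expected to remain a weak inhibitor, with an estimate of 25000 nM and a range from 6000 nM to 100000 nM. The expected step of an at least 1.2-fold lower number from compound 2 to compound 4 (0.07 log units; that floor lies within the scatter) is thus small, if any, and a further limit rather than a number is the more likely outcome.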

Compound 4, half-maximal inhibitory concentration: 3820 nM
Compound 4: the middle estimate sits 6.5-fold (0.82 log units) above what was measured; the whole stated range lies above it.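

Among the compounds shown here, replacing 1H-indol-6-yl with 4-chlorophenyl on the amine nitrogen gives, in this assay, an at least 7.8-fold lower number from compound 2 to compound 4 (0.89 log units; beyond the scatter), the first change in this small set whose effect can be read. This shows that the group on this nitrogen can move the result beyond the usual scatter, and that 1H-indol-6-yl is not required here for a measurable value. The printed step is only a minimum and the real gap may be larger, because the reading for compound 2 is a limit of the assay and not a number: the limit of > 30000 nM in this assay, at which 2 of the 4 values shown sit.

A single step cannot separate the effect of losing the 1H-indol-6-yl group from the effect of adding chlorine, and a plain phenyl group on the same nitrogen would help to tell these two apart. Going by these compounds, it also remains open whether the same exchange would lower the number on the core of compound 3, which differs from compound 4 in more than one place and so cannot be compared with it directly.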